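The compounds below may be only part of what the source reports. "The series", "measured", "known", "first", "only" and "open" are said of these compounds alone.

Compound 1 `COC[C@@H](C(C)C)C(c1ccc(O)c(OC)c1)c1ccc(O)c(OC)c1`: 69000 nM
Compound 2 `COC[C@@H](C)[C@H](C)C(c1ccc(O)c(OC)c1)c1ccc(O)c(OC)c1`: 58000 nM
Compound 3 `COC[C@H](C)[C@@H](C)C(c1ccc(O)c(OC)c1)c1ccc(O)c(OC)c1`: 77000 nM

All three numbers come from a functional assay on HeLa cells (Homo sapiens) for cytotoxicity, read by WST assay, with a stated time of 48 h; on this read-out lower numbers stand for stronger inhibition and higher numbers for weaker inhibition. Compound 3 gives the highest of the three, yet its neighbours sit close: a 1.1-fold higher number from compound 1 to compound 3 (0.05 log units; within the scatter) and a 1.3-fold higher number from compound 2 to compound 3 (0.12 log units; within the scatter). Compounds 2 and 3 share every atom and bond and are mirror images of each other (the fact that compounds 2 and 3 differ only in the configuration as drawn), and the gap between them stays within the scatter. The step of a 1.2-fold lower number from compound 1 to compound 2 (0.08 log units; within the scatter) is likewise within the scatter. Across these three compounds, reshaping the saturated chain attached to the carbon that carries the two aromatic rings produced no shift beyond the scatter.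

Compound 4 `COc1cc(C(c2ccc(O)c(OC)c2)[C@H](C)[C@@H](C)CO)ccc1O` keeps the core of compound 3 and carries a single change: hydrogen in place of methyl on an oxygen on a saturated carbon. Among the measured compounds shown here, no measured step exchanges a methoxy for a hydroxy, so the guidance is indirect: every chain alteration seen so far, a 1.2-fold lower number from compound 1 to compound 2 (0.08 log units; within the scatter), a 1.1-fold higher number from compound 1 to compound 3 (0.05 log units; within the scatter) and a 1.3-fold higher number from compound 2 to compound 3 (0.12 log units; within the scatter), remained within the scatter. On that basis the expected shift in this assay is a 1.1-fold lower number from compound 3 to compound 4 (0.04 log units; within the scatter), nothing beyond the scatter in either direction. Compound 4 is therefore estimated at 70000 nM in this assay, with a range from 35000 nM to 140000 nM.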

Compound 4, half-maximal inhibitory concentration: > 100000 nM
Compound 4: only a limit was reported (the forecaster's own chance of this, stated with the estimate: 10%); middle value at least 1.4-fold (0.15 log units) from the limit.
By their numbers in this assay, from the lowest: compounds 2, 1 and 3 (each within the scatter of the next). At a limit, above all of these: compound 4.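

In this assay compound 4 gives > 100000 nM, which is a limit of the assay and not a number. Compound 4 is the only compound shown with a hydroxymethyl end on the chain, and the exchange of methoxy for hydroxy reads as an at least 1.2-fold higher number from compound 3 to compound 4 (0.11 log units; that floor lies within the scatter), while the comparisons with the other two compounds, which also alter the chain, read as an at least 1.7-fold higher number from compound 2 to compound 4 (0.23 log units; that floor lies within the scatter) and an at least 1.4-fold higher number from compound 1 to compound 4 (0.16 log units; that floor lies within the scatter). Among the compounds shown here, each of these is only a floor and lies within the scatter, so the true size of the step stays unknown, but the result does show something the earlier compounds could not: removing this methyl gives no sign of stronger inhibition, and the one compound with a free hydroxy at this place is the only one to reach the limit.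

As far as these compounds go, whether the mirror image of compound 4 would read the same remains open, as does the real value of compound 4 itself. Also open, from the compounds shown here alone, is how an ethoxy, an amine or a carboxylic acid at this place on the chain would compare with methoxy and hydroxy.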